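Charged five-membered ring in place of trifluoromethylphenyl

The source may report more compounds than this note shows. Statements on the series, on what has been measured and on what is new or still open speak of the compounds shown alone.

Of the compounds shown here, three on the shared core have been measured in a functional assay on WI-38 VA13 cells (Homo sapiens) for cytotoxicity; a lower number here means that less compound is needed, a higher number that more compound is needed for the effect. Compound 1 `O=C(Nc1ccc2nc(NC(=O)C3CCCCC3)sc2c1)c1ccccc1F` gives 0.14 ug/mL. Compound 2 `O=C(Nc1ccc2nc(NC(=O)C3CCCCC3)sc2c1)c1ccccc1C(F)(F)F` gives 0.024 ug/mL, and compound 3 `O=C(Nc1ccc2nc(NC(=O)C3CCCCC3)sc2c1)c1c(Cl)cccc1Cl` gives 0.015 ug/mL. Among these three numbers compound 2 stands second highest: the step of a 5.8-fold lower number from compound 1 to compound 2 (0.77 log units; beyond the scatter) is beyond the scatter, while a 1.6-fold lower number from compound 2 to compound 3 (0.20 log units; within the scatter) is within it, so compounds 2 and 3 cannot be ordered.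

Compound 4 `Cc1[nH][n+](C)c(C)c1C(=O)Nc1ccc2nc(NC(=O)C3CCCCC3)sc2c1` is the next candidate. a group of 8 heavy atoms (6 carbon, 2 nitrogen; one five-membered aromatic ring with 2 hetero atoms) in place of a group of 10 heavy atoms (7 carbon, 3 fluorine; one six-membered aromatic ring of carbon only), on a carbonyl carbon

All measured steps keep a six-membered aromatic ring of carbon only and vary fluoro, trifluoromethyl or dichloro on it; none exchanges the ring itself for a five-membered aromatic ring with 2 hetero atoms carrying a net charge. The measured steps therefore do not bear directly on this change, and the expectation rests on the range of the series alone, with a lean toward a higher number given how far the new group departs from compounds 1 to 3. The step of a 21-fold higher number from compound 2 to compound 4 (1.32 log units; beyond the scatter) is an estimate only. Compound 4 is expected at 0.5 ug/mL, with a range from 0.05 ug/mL to 5 ug/mL.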

Compound 4, half-maximal effective concentration: 0.012 ug/mL
Estimate against measurement, compound 4: 42-fold (1.62 log units) above; the measured number lies below the stated range.
By their numbers in this assay, from the lowest: compounds 4, 3 and 2 (each within the scatter of the next); then compound 1.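

In this assay, a five-membered aromatic ring with 2 hetero atoms and net charge +1 can take the place of the substituted phenyl ring on the carbonyl carbon without a readable change: a 2.0-fold lower number from compound 2 to compound 4 (0.30 log units; within the scatter) and a 1.3-fold lower number from compound 3 to compound 4 (0.10 log units; within the scatter) both stay level. Against the 2-fluorophenyl compound, the picture differs: a 12-fold lower number from compound 1 to compound 4 (1.07 log units; beyond the scatter) leaves compound 1 as the only one of the four that stands apart from the rest. Among these compounds, neither a six-membered carbon ring nor the absence of charge is therefore required at this position for a low number, and nothing available explains this result.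

From the compounds shown here alone, it remains open whether any aromatic ring is needed here, as a simple methyl or a cyclohexyl on the carbonyl carbon would test. Also open, going by these compounds, is how the same five-membered ring with no net charge would compare with compound 4.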